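Swapping a Methylphenyl for Methylthiophene in Compound 4

The compounds below may be only part of what the source reports. "The series", "measured", "known", "first", "only" and "open" are said of these compounds alone.

compound 1 `Cc1cccc(-c2nc(CNc3ccc(C(=O)NO)cc3)n(-c3ccccc3)n2)c1`: 64.1%
compound 2 `O=C(NO)c1ccc(NCc2nc(-c3ccccc3)nn2-c2ccccc2Cl)cc1`: 64.6%
compound 3 `Cc1ccc(-n2nc(-c3ccccc3)nc2CNc2ccc(C(=O)NO)cc2)cc1C`: 53%

Compound 1 holds the second highest of the three numbers in an assay on Sf9 cells for inhibition of protein deacetylase HDAC6 (Homo sapiens), read by fluorescence, with a stated time of 40 min, tested at 100 nM; on this read-out lower numbers stand for less inhibition and higher numbers for more inhibition at the one concentration tested (going by the name of the read-out); compound 2 sits within the scatter of it, while compound 3 lies beyond the scatter below it. Compound 4 `Cc1ccc(-c2nc(CNc3ccc(C(=O)NO)cc3)n(-c3ccccc3)n2)s1` has not yet been measured. It differs from compound 1 by 5-methylthiophen-2-yl in place of 3-methylphenyl on an aromatic carbon. Among the measured compounds shown here, the only recorded step among the measured compounds, a number 11.6 percentage points lower from compound 2 to compound 3 (beyond the scatter), concerns the group on the aromatic nitrogen rather than the aromatic carbon changed here, so it bears on compound 4 only as a sign that exchanging one aromatic group for another can shift this assay modestly. Compound 4 is therefore expected to move by a number 4.1 percentage points lower from compound 1 to compound 4 (within the scatter), not beyond the scatter. The estimated value of compound 4 is 60%, between 45% and 75%.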

Compound 4, a percentage reported as inhibition, at one concentration (the size of the read-out at that concentration, not a potency): 79.7%
For compound 4 the middle estimate is 19.7 percentage points below the measured one; the measured number lies above the stated range.
By their numbers in this assay, from the lowest: compound 3; then compounds 1 and 2 (each within the scatter of the next); then compound 4.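

In this assay, the aromatic carbon between two ring nitrogen atoms proves sensitive to the group it carries: 5-methylthiophen-2-yl in place of 3-methylphenyl gives a number 15.6 percentage points higher from compound 1 to compound 4 (beyond the scatter). Among the compounds shown here, the only earlier step concerned the aromatic nitrogen and lowered the number, so this is the first sign that an aromatic exchange on this carbon can raise it. Nothing available accounts for the rise. Going by these compounds, whether it follows from the thiophene ring itself or from the placing of its methyl remains open. So does how a pyridine ring, or a carboxylic acid on the ring, would read here.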